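Working notes: from compound 2 to compound 4

The source may hold more compounds than are shown below. What is called first, only, known or untested is meant among the compounds shown, and "the series" means these compounds.

The series is measured in a functional assay on NCI-H460 cells (Homo sapiens) for inhibition, read by sulforhodamine B assay, with a stated time of 48 h; a lower number here means a stronger inhibitor of growth, a higher number a weaker inhibitor of growth. Within the data shown here, compound 2 `Nc1cc(N)c2nc(-c3ccccc3)c(NCc3ccc(Cl)c(Cl)c3)nc2c1` is the only member with a number in this assay, where compound 2 gives 46800 nM. Compound 1 `CCOC(=O)[C@H](CCC(=O)O)NC(=O)c1ccc(CNc2nc3cc(N)cc(N)c3nc2-c2ccccc2)cc1` reaches only a limit of the assay, giving < 100000 nM in this assay. Compound 3 `CCOC(=O)[C@H](CCC(=O)O)NC(=O)c1ccc(Sc2nc3cc(N)cc(N)c3nc2-c2ccccc2)cc1` likewise stops at a limit of the assay, giving < 100000 nM in this assay. Compound 2 thus stands as the one fixed point in the set, the other two values being limits, as summarised by the limit of < 100000 nM in this assay, at which 2 of the 3 values shown sit. Among the measured compounds shown here, no pair of measured compounds differs in a single place, so no measured step is available to set a scale for any change.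

Compound 4 `COc1ccc(CNc2nc3cc(N)cc(N)c3nc2-c2ccccc2)cc1` is not yet measured in this assay. It differs from compound 2 by 4-methoxyphenyl in place of 3,4-dichlorophenyl on a saturated chain carbon bound to a nitrogen on an aromatic ring, in words 4-methoxyphenyl in place of 3,4-dichlorophenyl on a saturated chain carbon bound to a nitrogen on an aromatic ring. For the measured compounds named here, nothing among the measured compounds tests this change. The expected step is small, near the edge of the usual scatter, and if anything toward weaker growth inhibition: a 1.4-fold higher number from compound 2 to compound 4 (0.14 log units; within the scatter). Compound 4 is therefore estimated at 65000 nM in this assay, with a range from 20000 nM to 200000 nM, and with a real chance that this assay returns only a limit for compound 4.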

Compound 4, concentration for total growth inhibition: 47900 nM
For compound 4 the middle estimate is 1.4-fold (0.13 log units) above the measured one; low and high end bracket the measured number.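

In this assay, among these compounds, the change of 3,4-dichlorophenyl to 4-methoxyphenyl on a saturated chain carbon bound to a nitrogen on an aromatic ring gives a 1.0-fold higher number from compound 2 to compound 4 (0.01 log units; within the scatter), the first measured single-place step. At this position, the 3,4-dichlorophenyl group, with 0 hydrogen-bond acceptors, and the 4-methoxyphenyl group, with 1 hydrogen-bond acceptor, are therefore not separated in growth inhibition, although their ring substituents differ in both kind and place. Compound 4 also gives a second number to set beside compound 2, while the remaining values stay limits of the assay: the limit of < 100000 nM in this assay, at which 2 of the 4 values shown sit.

From the compounds shown here alone, whether any group at this position can move the number beyond the scatter remains open, and an unsubstituted phenyl, a carboxylic acid on the ring or a longer chain between the ring and the nitrogen would each test this. The phenyl on the shared core is the same in all the compounds shown, so the effect of an amine on that ring also remains open.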